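The source may report more compounds than this note shows. Statements on the series, on what has been measured and on what is new or still open speak of the compounds shown alone.

Measured in an ADME assay for pharmacokinetics; a lower number here means that the compound disappears faster, a higher number that the compound lasts longer:
- Compound 1 `N=C(N)SCCCOc1oc(=O)c2cc(NC(=O)NCc3ccccc3)ccc2c1Cl`: 2.47 h
- Compound 2 `N=C(N)SCCCOc1oc(=O)c2cc(NC(=O)CCc3ccccc3)ccc2c1Cl`: 1.1 h
- Compound 3 `N=C(N)SCCCOc1oc(=O)c2cc(N)ccc2c1Cl`: 1.5 h

In this assay, compound 3 gives 1.5 h, which lies within the scatter of the values of both other compounds. Compound 4 `N=C(N)SCCCOc1oc(=O)c2cc(NC(=O)Nc3ccccc3)ccc2c1Cl` has phenylcarbamoyl in place of hydrogen on a nitrogen on an aromatic ring.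

Among the measured compounds shown here, two measured steps bear on this change, each exchanging a group on that same nitrogen for hydrogen. For benzylcarbamoyl the data show a 1.6-fold lower number from compound 1 to compound 3 (0.22 log units; within the scatter), and for phenethylcarbonyl they show a 1.4-fold higher number from compound 2 to compound 3 (0.13 log units; within the scatter). For the measured compounds named here, the only step beyond the scatter is modest, a 2.2-fold lower number from compound 1 to compound 2 (0.35 log units; beyond the scatter), and it separates two compounds that both carry a group on that nitrogen. Benzylcarbamoyl is the closest measured match to the entering group, so the estimate leans slightly towards compound 1 at 2.47 h. The step expected is a 1.3-fold higher number from compound 3 to compound 4 (0.12 log units; within the scatter), so no clear change is anticipated. For compound 4 the estimated half-life is 2 h, with an expected range of 1.1 h to 3.6 h.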

Compound 4, half-life: 2.47 h
Compound 4: the middle estimate sits 1.2-fold (0.09 log units) below what was measured; the range from low to high includes it.
By their numbers in this assay, from the lowest: compounds 2, 3, 1 and 4 (each within the scatter of the next, the first and the last beyond it).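

In this assay, phenylcarbamoyl on the nitrogen on the aromatic ring leaves no clear difference from the free amino compound (a 1.6-fold higher number from compound 3 to compound 4 (0.22 log units; within the scatter)), and phenyl in place of benzyl on the amide-type nitrogen gives (no change at the digits printed from compound 1 to compound 4 (within the scatter)). Anilino in place of phenethyl on the carbonyl carbon, by contrast, gives (a 2.2-fold higher number from compound 2 to compound 4 (0.35 log units; beyond the scatter)), so compound 1 and compound 4, which both have a nitrogen on that carbonyl carbon, each stand apart from compound 2, while compound 3, which lacks the carbonyl, lies within the scatter of all three. No supporting measurement accounts for these differences.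

Going by these compounds, it remains open whether a fluorine or methoxy group on the phenyl ring would shift the half-life. The same holds for a simple alkyl group such as methyl or cyclohexyl in place of the phenyl.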